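Swapping a triazole for a tetrazolylmethyl on the side chain

This account rests on a few compounds, and the source may have more. Where it says the series, first, only, none or still open, it means among the compounds named here.

The three measured compounds, tested in an assay on isolated protein for inhibition of leukotriene B4 receptor 1 (Homo sapiens), tested at 10 uM; on this read-out higher numbers stand for more inhibition at the one concentration tested (going by the name of the read-out) and lower numbers for less inhibition:
Compound 1 `CCc1cc(C(C)=O)c(O)cc1OCCCCC#N` gives 92% in this assay.
Compound 2 `CCc1cc(C(C)=O)c(O)cc1OCCCCCCC#N` gives 103% in this assay.
Compound 3 `CCc1cc(C(C)=O)c(O)cc1OCCCCCn1cncn1` gives 82% in this assay.

Compound 3 sits at the bottom of these three numbers. Its gap to compound 1 is within the scatter, as the step of a number 10 percentage points lower from compound 1 to compound 3 (within the scatter) shows, while the step of a number 21 percentage points lower from compound 2 to compound 3 (beyond the scatter) lies beyond it. All three share a core and differ only in what ends the side chain.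

Compound 4 `CCc1cc(C(C)=O)c(O)cc1OCCCCCCc1nnn[nH]1` carries a further variation of that chain end: (1H-tetrazol-5-yl)methyl in place of 1H-1,2,4-triazol-1-yl on a saturated chain carbon, five bonds along the chain from an oxygen on an aromatic ring. The two steps into compound 3 bear on this change. One was within the scatter, the other a modest drop; together they show that replacing the nitrile-ended chain with a ring costs little. Adding a ring that brings one hydrogen-bond donor is untested here, so no direction is firmly expected. A step of a number 4 percentage points higher from compound 3 to compound 4 (within the scatter) is estimated, within the scatter. Compound 4 is therefore expected to give 86%, between 68% and 103%.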

Compound 4, a percentage reported as inhibition, at one concentration (the size of the read-out at that concentration, not a potency): 91%
Estimate against measurement, compound 4: 5 percentage points below; the range from low to high includes it.
By their numbers in this assay, from the lowest: compounds 3, 4 and 1 (each within the scatter of the next); then compound 2.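

In this assay, a chain end that brings a hydrogen-bond donor on its ring is accommodated at this position: the change from the triazole to the tetrazole gives a step within the scatter (a number 9 percentage points higher from compound 3 to compound 4 (within the scatter)), and the tetrazole compound also stays level with the shorter nitrile (a number 1 percentage points lower from compound 1 to compound 4 (within the scatter)). The one gap here that clears the scatter is to the longer nitrile (a number 12 percentage points lower from compound 2 to compound 4 (beyond the scatter)), so neither ring end shown matches that compound in this read-out. No separate measurement bears on why these numbers fall as they do.

From the compounds shown here alone, whether a carboxylic acid or a primary amine at the same chain end would read like the tetrazole remains open. So does whether a longer chain carrying the tetrazole would close the gap to the longer nitrile, and a single concentration cannot rank the potencies of these compounds.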